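Amide variation on a shared hydroxynaphthyl core

The compounds below may be only part of what the source reports. "The series", "measured", "known", "first", "only" and "open" are said of these compounds alone.

Compound 1 `O=C(Nc1cc(Sc2ncn[nH]2)c(O)c2ccccc12)c1cccc(Cl)c1` gives 46% in an assay on isolated protein for inhibition of RAC-alpha serine/threonine-protein kinase (Homo sapiens), read by fluorescence, with a stated time of 30 min, tested at 10 uM (a lower number here means less inhibition, a higher number more inhibition at the concentration tested (going by the name of the read-out)), the higher of the two numbers available. Compound 2 `O=C(Nc1cc(Sc2nncs2)c(O)c2ccccc12)c1ccc(Cl)cc1` gives 7.5% in this assay, a gap beyond the usual scatter, though compound 2 also differs from compound 1 in more than one place. Compound 3 `O=C(/C=C/c1ccccc1)Nc1cc(Sc2ncn[nH]2)c(O)c2ccccc12` changes compound 1 by 2-phenylethenyl in place of 3-chlorophenyl on a carbonyl carbon. Within the data shown here, no single-point step between measured compounds is available for this position, so the step from compound 1 is expected to be small, at most a modest loss and possibly none beyond the scatter. Compound 3 is estimated at 36%, within 12% to 58%, which would mean an expected step of a number 10 percentage points lower from compound 1 to compound 3 (within the scatter).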

Compound 3, a percentage reported as inhibition, at one concentration (the size of the read-out at that concentration, not a potency): 26.2%
Beside the measured number, compound 3's estimate is 9.8 percentage points above it; the measured number falls inside the stated range.
By their numbers in this assay, from the lowest: compound 2; then compound 3; then compound 1.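

Among these compounds, on the carbonyl carbon whose other neighbour is the amide-type nitrogen, 2-phenylethenyl in place of 3-chlorophenyl gives a number 19.8 percentage points lower from compound 1 to compound 3 (beyond the scatter) in this assay, the first change that can be read at a single place. This position therefore affects the read-out, and an aromatic ring carried through a double bond does not match 3-chlorophenyl here. Nothing available accounts for the step.

Still open, on these data alone, is how an amine, a carboxylic acid or a longer saturated chain on this carbonyl carbon would compare with 3-chlorophenyl.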